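Two aromatic sides, one methoxy moved: what changes?

The compounds below may be only part of what the source reports. "The series", "measured", "known", "first", "only" and "open" are said of these compounds alone.

Measured compounds:
- compound 1 `COc1ccc2c(/C=C(\C#N)C(=O)c3c[nH]c4cc(F)ccc34)c[nH]c2c1`: 5500 nM
- compound 2 `COc1ccc2[nH]cc(/C=C(\C#N)C(=O)c3c[nH]c4ccccc34)c2c1`: 13700 nM
- compound 3 `N#C/C(=C\c1c[nH]c2cc(F)ccc12)C(=O)c1c[nH]c2cc(F)ccc12`: 36100 nM

These three compounds share one core and differ only in the groups on the two aromatic sides. In a functional assay on A549 cells (Homo sapiens) for cytotoxicity, read by WST assay, with a stated time of 48 h (on this read-out higher numbers stand for weaker inhibition and lower numbers for stronger inhibition), compound 2 gives 13700 nM, which is the second highest of the three numbers; the nearest is compound 1, whose number is lower by a gap beyond the scatter, and the furthest is compound 3, whose number is higher by a gap also beyond the scatter.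

Compound 4 `COc1ccc2[nH]cc(/C=C(\C#N)C(=O)c3c[nH]c4ccc(OC)cc34)c2c1` has not yet been measured. It differs from compound 2 in one place: methoxy in place of hydrogen on an aromatic carbon

Among the compounds with values here, only one measured step concerns a single change, a 6.6-fold higher number from compound 1 to compound 3 (0.82 log units; beyond the scatter), where fluoro in place of methoxy on an aromatic carbon raised the number. That step sits on the other side of the core and swaps a different pair of groups, so it bears only loosely on the present change. Compound 1 and compound 2 differ on the same side that changes here, and compound 1 gives the lower number, which hints that a group other than hydrogen on that side may lower the number somewhat. The expected step of a 1.5-fold lower number from compound 2 to compound 4 (0.18 log units; within the scatter) is therefore a small one toward a lower number, possibly within the scatter. Compound 4 is estimated at 9000 nM, in the range 3000 nM to 30000 nM.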

Compound 4, half-maximal inhibitory concentration: 24500 nM
Compound 4: middle estimate off by 2.7-fold (0.43 log units), on the low side; low and high end bracket the measured number.
By their numbers in this assay, from the lowest: compound 1; then compounds 2, 4 and 3 (each within the scatter of the next, the first and the last beyond it).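

Placing methoxy in place of hydrogen on this aromatic carbon, in this assay, gives a 1.8-fold higher number from compound 2 to compound 4 (0.25 log units; within the scatter), so this single change produces no difference that can be told from the usual variation between repeated measurements. Within the data shown here, this is the first direct reading at this position, since the only earlier single change, a 6.6-fold higher number from compound 1 to compound 3 (0.82 log units; beyond the scatter), swapped a different pair of groups elsewhere on the shared core and lay beyond the scatter. Nothing available here explains why the methoxy group leaves the number within the scatter.

This one pair cannot show whether the position accepts other groups in the same way, so an amine or a carboxylic acid on this aromatic carbon might give a number that stands clearly apart from that of compound 2. As far as these compounds go, it also remains open whether methoxy at this place would again stay within the scatter if the groups on the other aromatic side were different, for example with the fluoro group found in compound 1 and compound 3.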